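The source may report more compounds than this note shows. Statements on the series, on what has been measured and on what is new or still open speak of the compounds shown alone.

Of the compounds shown here, two have been measured in an ADME assay on BHK cells (Mesocricetus auratus) for cytotoxicity, read by MTT assay, with a stated time of 96 h; on this read-out higher numbers stand for lower toxicity in this test and lower numbers for higher toxicity in this test. Compound 1 `O=C(CN1CCCCC1)Nc1ccc(-c2nc3cc(C(F)(F)F)ccc3[nH]2)cc1` gives 12000 nM in this assay. Compound 2 `COc1ccc(-c2nc3cc(C(C)=O)ccc3[nH]2)c(OC)c1OC` sits at the limit of > 100000 nM in this assay, at which 1 of the 2 values shown sits, so for compound 2 the result in this assay is a limit, > 100000 nM, and not a number. Compound 3 `COc1ccc(-c2nc3cc([N+](=O)[O-])ccc3[nH]2)c(OC)c1OC` is not yet measured and differs from compound 2 by nitro in place of acetyl on an aromatic carbon. Among the compounds with values here, no step between measured compounds is available for this change. The step expected from compound 2 to compound 3 is an at least 1.2-fold lower number from compound 2 to compound 3 (0.09 log units; that floor lies within the scatter), not beyond the usual scatter in either direction. Compound 3 is accordingly estimated at 80000 nM, with a range of 20000 nM to 300000 nM.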

Compound 3, half-maximal cytotoxic concentration: > 100000 nM
Compound 3: only a limit was reported; the forecaster's own chance of this, stated with the estimate: 60%; middle value at least 1.2-fold (0.09 log units) away from the limit.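

Compound 2 and compound 3 both give only a limit, not a number, in this assay, so no step for nitro in place of acetyl can be read between them: the limit of > 100000 nM in this assay, at which 2 of the 3 values shown sit.

The compounds shown leave open whether nitro in place of acetyl on an aromatic carbon shifts this read-out at all.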